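Chloro in Place of Nitro on Compound 1

The compounds below may be only part of what the source reports. "The series", "measured", "known", "first", "only" and "open" are said of these compounds alone.

Compound 1 `O=C(NNC(=O)c1ccc([N+](=O)[O-])cc1)c1ccc(-n2cccc2)cc1` gives 198000 nM
Compound 2 `CC(=O)N1N=C(c2ccc(-n3c(C)ccc3C)cc2)OC1c1ccc(Br)cc1` gives 195000 nM
Compound 3 `CC(=O)NNC(=O)c1ccc(-n2c(C)ccc2C)cc1` gives 180000 nM

These values come from an ADME assay on A549 cells (Homo sapiens) for cytotoxicity, read by MTT assay, with a stated time of 72 h (on this read-out lower numbers stand for stronger inhibition and higher numbers for weaker inhibition), and all lie within the usual scatter of one another, so compound 1 stands level with the other two. Compound 4 `O=C(NNC(=O)c1ccc(-n2cccc2)cc1)c1ccc(Cl)cc1` differs from compound 1 by a single change chloro in place of nitro on an aromatic carbon with chloro in place of nitro on an aromatic carbon. Among the measured compounds shown here, no measured pair shows a one-place step, so this is a judgement from limited data. Compound 2 (195000 nM) and compound 3 (180000 nM) differ in structure from compound 1 (198000 nM), yet their values stay within the scatter. In this assay no step beyond the scatter is therefore expected. The estimated step is small, a 1.2-fold lower number from compound 1 to compound 4 (0.07 log units; within the scatter) (an expectation only). Compound 4 is expected at 170000 nM (estimated range 80000 nM to 320000 nM).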

Compound 4, half-maximal inhibitory concentration: 185000 nM
Estimate against measurement, compound 4: 1.1-fold (0.04 log units) below; the range from low to high includes it.
By their numbers in this assay, from the lowest: compounds 3, 4, 2 and 1 (each within the scatter of the next).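

In this assay, among the compounds shown here, the one pair that differs in a single place gives a 1.1-fold lower number from compound 1 to compound 4 (0.03 log units; within the scatter) and so shows directly that chloro in place of nitro, on this aromatic carbon para to a large group, leaves the read-out level. Here, taking away nitro with its 2 hydrogen-bond acceptors brings no step beyond the scatter. No measurement shown gives a reason for this result. On these data alone, whether an amine or a carboxylic acid at this position would give a step beyond the scatter stays open.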